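Chloro for Bromo: an Expected Growth-Inhibition Value

This account rests on a few compounds, and the source may have more. Where it says the series, first, only, none or still open, it means among the compounds named here.

Measured compounds:
- Compound 1 `COc1cc(C2CC(c3ccc(Br)cc3)=NN2C(C)=O)ccc1OCc1cn(Cc2ccc([N+](=O)[O-])cc2)nn1`, in a functional assay on COLO 205 cells (Homo sapiens) for inhibition, read by sulforhodamine B assay, tested at 10 uM; on this read-out lower numbers stand for less inhibition of growth and higher numbers for more inhibition of growth at the one concentration tested: 26%
- Compound 2 `COc1cc(C2CC(c3cc(OC)c(OC)c(OC)c3)=NN2C(C)=O)ccc1OCc1cn(Cc2ccc([N+](=O)[O-])cc2)nn1`, in this assay: 60%
- Compound 3 `COc1ccc(C2CC(c3ccc(OCc4cn(Cc5ccc([N+](=O)[O-])cc5)nn4)cc3)=NN2C(C)=O)cc1OC`, in this assay: 9%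

Compound 1 holds the second highest of the three numbers. Compound 2 sits above it by a number 34 percentage points higher from compound 1 to compound 2 (beyond the scatter), a change in which a 3,4,5-trimethoxyphenyl replaces the 4-bromophenyl. Compound 3 lies below compound 1, but it differs from it in more than one place, so no single step can be read from that pair.

Compound 4 `COc1cc(C2CC(c3ccc(Cl)cc3)=NN2C(C)=O)ccc1OCc1cn(Cc2ccc([N+](=O)[O-])cc2)nn1` carries the change (chloro in place of bromo on an aromatic carbon), that is, chloro in place of bromo on an aromatic carbon. For the measured compounds named here, no measured step exchanges one halogen for another; the only single-place step, a number 34 percentage points higher from compound 1 to compound 2 (beyond the scatter), alters the whole substituted ring and says nothing about so small a swap. With no guidance from the data, the expectation for compound 4 is a step of no size beyond the scatter, a number 1 percentage points lower from compound 1 to compound 4 (within the scatter). Compound 4 is therefore estimated at 25%, within a range from 8% to 42%.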

Compound 4, percent growth inhibition at one concentration: 0%
Compound 4: middle estimate off by 25 percentage points, on the high side; measured number outside the range, below it.
By their numbers in this assay, from the lowest: compounds 4 and 3 (each within the scatter of the next); then compound 1; then compound 2.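

In this assay, this aromatic carbon proves sensitive even to an exchange of one halogen for another: chloro in place of bromo gives a number 26 percentage points lower from compound 1 to compound 4 (beyond the scatter), a change of a single atom that is still beyond the scatter. The earlier step showed only that replacing the whole substituted ring could matter, whereas 4-chlorophenyl in place of 3,4,5-trimethoxyphenyl now gives a number 60 percentage points lower from compound 2 to compound 4 (beyond the scatter), so the group on this carbon separates the most and least growth-inhibiting of these three closely related compounds. Nothing available explains why the two halogens differ here.

With only bromo and chloro compared, no trend across halogens can be drawn. As far as these compounds go, whether fluoro, a methyl group or an amine on the same carbon would lie nearer compound 1 or compound 4 stays open.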